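Benzothiazole hydrazones against maltase-glucoamylase: a hydroxyl variation

The source may report more compounds than this note shows. Statements on the series, on what has been measured and on what is new or still open speak of the compounds shown alone.

Measured so far:
compound 1, `O=C(N/N=C\c1ccccn1)c1ccc(-c2nc3ccccc3s2)cc1`: 10200 nM
compound 2, `COC(=O)c1ccc(/C=N/NC(=O)c2ccc(-c3nc4ccccc4s3)cc2)cc1`: "not active" (no number reported)
compound 3, `COc1ccc(/C=N/NC(=O)c2ccc(-c3nc4ccccc4s3)cc2)cc1O`: "not active" (no number reported)

Three compounds share the core of compound 1 and differ only in the aryl group on the carbon with a double bond to nitrogen. In an assay on isolated protein for inhibition of Maltase-glucoamylase (Homo sapiens), with a stated time of 15 min (a higher number here means a weaker inhibitor, a lower number a stronger inhibitor), compound 1 gives 10200 nM. Compound 2 returns "not active" (no number reported) in this assay, with no number reported. Compound 3 likewise returns "not active" (no number reported) in this assay; it stands among the entries without a single number, alongside compound 2, and only compound 1 carries a number at all. Among the compounds with values here, no step between measured compounds can be sized from these entries.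

Compound 4, `O=C(N/N=C/c1cc(O)ccc1O)c1ccc(-c2nc3ccccc3s2)cc1`, is the next member. Its change from compound 3 is 2,5-dihydroxyphenyl in place of 3-hydroxy-4-methoxyphenyl on a carbon with a double bond to nitrogen. Within the data shown here, with no number for compound 3 and no step recorded, the size and direction of the step in this assay cannot be stated; the only numerical anchor is compound 1. The expectation is weak inhibition at best, with a real chance that this assay again reports no number. Compound 4 is expected at 15000 nM in this assay, within 3000 nM to 80000 nM.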

Compound 4, half-maximal inhibitory concentration: 11900 nM
Beside the measured number, compound 4's estimate is 1.3-fold (0.10 log units) above it; measured number inside the range.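

In this assay, within the data shown here, compound 3 gives "not active" (no number reported) and compound 4 gives 11900 nM with no step readable between them. No supporting data bear on this result. The compounds shown leave open which aryl groups on the carbon with a double bond to nitrogen yield a reported number.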